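This account rests on a few compounds, and the source may have more. Where it says the series, first, only, none or still open, it means among the compounds named here.

Measured compounds:
Compound 1, `O=C(O)c1ccc(NCc2cccc(Oc3ccccc3)c2)cc1`, gives 86% in a functional assay on CHO cells for agonist activity at Free fatty acid receptor 1 (Homo sapiens), read by a luciferase reporter; a higher number here means a larger maximal response, a lower number a smaller maximal response.
Compound 2, `CNC(=O)CCc1ccc(NCc2cccc(Oc3ccccc3)c2)cc1`, gives 67% in this assay.

Compound 2 stands at the lower of the two numbers seen so far; its nearest neighbour is compound 1, and the step of a number 19 percentage points lower from compound 1 to compound 2 (beyond the scatter) separates them, a step that swapped the carboxy group on the aromatic carbon for the longer chain ending in a methylcarbamoyl group.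

Compound 3, `O=C(CCc1ccc(NCc2cccc(Oc3ccccc3)c2)cc1)N1CCCC1`, has not yet been measured. It differs from compound 2 only at the amide end of that chain: pyrrolidin-1-yl in place of methylamino on a carbonyl carbon. Among the measured compounds shown here, no measured step touches this position; the one step known, from compound 1 to compound 2, concerns the group attached to the aromatic carbon, not the substituent on the carbonyl carbon, so it does not tell whether a larger ring in place of the methylamino group moves the maximal response. With nothing to lean on but the value of compound 2, the expectation is a step from compound 2 to compound 3 of a number 2 percentage points lower from compound 2 to compound 3 (within the scatter), that is, no change beyond the scatter in either direction. Compound 3 is therefore estimated at 65%, with a range from 45% to 85%.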

Compound 3, largest response reached (reported as percent of maximum), in percent of the reference or control that the assay uses: 46%
Beside the measured number, compound 3's estimate is 19 percentage points above it; the measured number falls inside the stated range.
By their numbers in this assay, from the lowest: compound 3; then compound 2; then compound 1.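

The amide end of the chain, untouched by the earlier comparison, turns out to matter for the maximal response: in this assay, pyrrolidin-1-yl in place of methylamino on the carbonyl carbon gives a number 21 percentage points lower from compound 2 to compound 3 (beyond the scatter). The change swaps an open group carrying a hydrogen-bond donor for a five-membered ring carrying none, and the full replacement of carboxy by 2-((pyrrolidin-1-yl)carbonyl)ethyl on the aromatic carbon gives a number 40 percentage points lower from compound 1 to compound 3 (beyond the scatter), which places compound 3 lowest of the three. Nothing available explains why the response falls at this position.

The compounds shown leave open whether the fall follows the ring itself, the added carbons or the loss of the amide hydrogen, a question that dimethylamino, azetidin-1-yl or piperidin-1-yl on the same carbonyl carbon would bear on. They also leave open how much of the difference from compound 1 belongs to the chain and how much to the amide, which a carboxylic acid at the end of the same chain would help to separate.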